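The compounds below may be only part of what the source reports. "The series", "measured", "known", "first", "only" and "open" are said of these compounds alone.

Series notes. Compound 2 `COc1ccc(S(=O)(=O)N2CCc3cccc(NC(=O)c4ccc([N+](=O)[O-])cc4)c32)cc1` gives 102 nM in a functional assay on KB cells (Homo sapiens) for cytotoxicity; a lower number here means a stronger inhibitor, a higher number a weaker inhibitor. Compound 1 `COc1ccc(S(=O)(=O)N2CCc3cccc(NC(=O)c4ccc(C#N)cc4)c32)cc1` gives 105 nM in this assay, and compound 3 `COc1ccc(S(=O)(=O)N2CCc3cc(Br)cc(NC(=O)c4ccco4)c32)cc1` gives 89 nM. All three numbers sit within the scatter of one another; compound 2 lies nearest to compound 1 and furthest from compound 3, but neither gap is more than the scatter allows. Within the data shown here, the only single-point step measured so far is a 1.0-fold lower number from compound 1 to compound 2 (0.01 log units; within the scatter), which shows that swapping the group on the benzamide ring between nitro and cyano leaves the number where it was. Compound 3 differs from compound 2 in two places at once, so its value says nothing separate about the amide aryl group.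

Compound 4 `COc1ccc(S(=O)(=O)N2CCc3cccc(NC(=O)c4ccncc4)c32)cc1` is not yet measured. It differs from compound 2 by pyridin-4-yl in place of 4-nitrophenyl on a carbonyl carbon. Among the measured compounds shown here, no measured step covers this exchange; the one nearby step, nitro for cyano, was flat. With nothing pointing either way, the expected step is a 1.4-fold higher number from compound 2 to compound 4 (0.14 log units; within the scatter), that is, none beyond the scatter. Compound 4 is therefore estimated at 140 nM in this assay, with a range from 50 nM to 400 nM.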

Compound 4, half-maximal inhibitory concentration: 9.6 nM
Compound 4: the middle estimate sits 15-fold (1.16 log units) above what was measured; measured number outside the range, below it.
By their numbers in this assay, from the lowest: compound 4; then compounds 3, 2 and 1 (each within the scatter of the next).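

In this assay the group on the carbonyl carbon is not as flat as the nitro and cyano pair suggested: an 11-fold lower number from compound 2 to compound 4 (1.03 log units; beyond the scatter), and an 11-fold lower number from compound 1 to compound 4 (1.04 log units; beyond the scatter). The gain appears from both 4-nitrophenyl and 4-cyanophenyl, so it does not rest on a single starting compound, and it shows that this position can move the number beyond the scatter when the ring itself is exchanged rather than only the group on it. No measurement at hand accounts for the step.

The compounds shown leave open whether the step goes with the ring nitrogen of pyridin-4-yl or with the loss of the nitro or nitrile group; an unsubstituted phenyl on the carbonyl carbon is the group that would separate the two. On these data alone, how pyridin-3-yl, pyridin-2-yl or a saturated piperidin-4-yl would read here also remains open.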